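This account rests on a few compounds, and the source may have more. Where it says the series, first, only, none or still open, it means among the compounds named here.

Measured compounds:
- Compound 1, `O=C(Nc1cc(C(F)(F)F)cc(C(F)(F)F)c1)c1cc(Br)ccc1O`: 300 nM
- Compound 2, `O=C(Nc1cc(C(F)(F)F)cc(C(F)(F)F)c1)c1ccc(Cl)cc1O`: 620 nM
- Compound 3, `N#Cc1ccc(NC(=O)c2cc(Cc3ccccc3)ccc2O)cc1`: 1930 nM

In a functional assay on KG-1 cells (Homo sapiens) for cytotoxicity, read by luminescence and CellTiter-Glo, with a stated time of 3 days (on this read-out higher numbers stand for weaker inhibition and lower numbers for stronger inhibition), compound 2 stands second highest of the three numbers. Its nearest neighbour is compound 1, whose number is lower, and the step of a 2.1-fold higher number from compound 1 to compound 2 (0.32 log units; beyond the scatter) is beyond the scatter. Compound 3 gives the highest number of the three, further from compound 2 than compound 1 is.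

Compound 4, `O=C(Nc1cc(C(F)(F)F)cc(C(F)(F)F)c1)c1ccc(-c2ccccc2)cc1O`, has not yet been measured. It differs from compound 2 in one place: phenyl in place of chloro on an aromatic carbon. The new group sits on the aromatic carbon of the shared core that is meta to the hydroxy group and para to the large group.

For the measured compounds named here, no measured step follows this same change. Going by the values given here, the only step available, from compound 1 to compound 2, exchanges one halogen position for another and says nothing about a chloro giving way to a phenyl. Compound 3 carries a benzyl on its core but also a different amide partner, so its number cannot be separated into the two changes. With no direct guide, a step of a 1.2-fold lower number from compound 2 to compound 4 (0.09 log units; within the scatter) is expected in this assay, which is within the scatter. Compound 4 is therefore estimated at 500 nM, with a range from 150 nM to 2000 nM.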

Compound 4, half-maximal inhibitory concentration: 860 nM
The estimate for compound 4 lay 1.7-fold (0.24 log units) below the measured number, within the range that was stated.
By their numbers in this assay, from the lowest: compound 1; then compounds 2 and 4 (each within the scatter of the next); then compound 3.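

In this assay putting phenyl in place of chloro, on the aromatic carbon that is meta to the hydroxy group and para to a large group, gives a 1.4-fold higher number from compound 2 to compound 4 (0.14 log units; within the scatter) and so leaves no change that can be told from the scatter. For the compounds shown here, this position therefore takes a group of 6 heavy atoms with a six-membered aromatic ring in place of a single chlorine, and the number in this cell assay stays where it was, something the earlier compounds could not show. Going by these compounds alone, the only earlier step, a 2.1-fold higher number from compound 1 to compound 2 (0.32 log units; beyond the scatter) with a chloro and a bromo on different carbons, compared two halogens and said nothing about a ring at this place, and no measurement at hand accounts for the new result.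

The compounds shown leave open whether a small group such as methyl, or an amine or a carboxylic acid, on this same aromatic carbon would also keep the number in this range. Going by these compounds, it also remains open whether the entering phenyl could carry a further group, such as a methoxy, with the same outcome.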